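Ghrelin receptor series: aryl ether variation, compound 4 outlook

The compounds below may be only part of what the source reports. "The series", "measured", "known", "first", "only" and "open" are said of these compounds alone.

Measured so far:
compound 1 `CC(C)(N)C(=O)N[C@H](COCc1cccc(C(F)(F)F)c1)c1nnnn1CCOC(=O)NCCCCO` — 1.79 nM
compound 2 `CC(C)(N)C(=O)N[C@H](COCc1cc(C(F)(F)F)cc(C(F)(F)F)c1)c1nnnn1CCOC(=O)NCCCCO` — 34 nM
compound 3 `CC(C)(N)C(=O)N[C@H](COCc1ccc(OC(F)(F)F)cc1)c1nnnn1CCOC(=O)NCCCCO` — 33.2 nM

All three share one core and differ only in the aryl group on the ether. In a functional assay on cells for inhibition of growth hormone secretagogue receptor type 1 (Homo sapiens), read by FLIPR and calcium flux (on this read-out higher numbers stand for an effect only at larger amounts of compound and lower numbers for an effect already at smaller amounts), compound 1 gives the lowest number of the three; compound 3 and compound 2 both sit well above it, beyond the scatter.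

Compound 4 `CC(C)(N)C(=O)N[C@H](COCc1ccccc1-c1cccnc1)c1nnnn1CCOC(=O)NCCCCO` carries 2-(pyridin-3-yl)phenyl in place of 3-(trifluoromethyl)phenyl on a saturated chain carbon bound to an oxygen on a saturated carbon. Among the compounds with values here, no measured step covers this exact change, but both changes made at the same position, a 19-fold higher number from compound 1 to compound 2 (1.28 log units; beyond the scatter) and a 19-fold higher number from compound 1 to compound 3 (1.27 log units; beyond the scatter), were large and went in the same direction. A comparable loss is therefore expected for compound 4 in this assay, with a 17-fold higher number from compound 1 to compound 4 (1.22 log units; beyond the scatter). Compound 4 is estimated at 30 nM, within 6 nM to 150 nM.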

Compound 4, half-maximal effective concentration: 1.18 nM
Beside the measured number, compound 4's estimate is 25-fold (1.41 log units) above it; the measured number lies below the stated range.
By their numbers in this assay, from the lowest: compounds 4 and 1 (each within the scatter of the next); then compounds 3 and 2 (each within the scatter of the next).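

In this assay, this position proves less restrictive than compound 2 and compound 3 suggested: 2-(pyridin-3-yl)phenyl in place of 3-(trifluoromethyl)phenyl gives a 1.5-fold lower number from compound 1 to compound 4 (0.18 log units; within the scatter). Replacing 4-(trifluoromethoxy)phenyl with the same group gives a 28-fold lower number from compound 3 to compound 4 (1.45 log units; beyond the scatter), so a high number is not the general outcome of changing the aryl group here. No available evidence explains either step.

Still open, as far as these compounds go, is whether the pyridine nitrogen matters, which a plain phenyl in place of the pyridin-3-yl ring would test. Also open, from the compounds shown here alone, is how an amine or a carboxylic acid on that ring would read.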